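This account rests on a few compounds, and the source may have more. Where it says the series, first, only, none or still open, it means among the compounds named here.

Compound 1 `CC(C)S(=O)(=O)c1ccc(S(=O)(=O)N2CCC[C@@H](C(=O)N3CCC(F)(F)CC3)C2)cc1`: 50 nM
Compound 2 `CCN(CC)S(=O)(=O)c1ccc(S(=O)(=O)N2CCC[C@@H](C(=O)NC3CCOCC3)C2)cc1`: 8570 nM

In a functional assay on BXPC-3 cells (Homo sapiens) for inhibition, read by MTT assay, with a stated time of 7 days (a higher number here means a weaker inhibitor, a lower number a stronger inhibitor), compound 2 gives the higher of the two numbers, and compound 1 gives a number far below it, well beyond the scatter. Compound 3 `CCN(CC)S(=O)(=O)c1ccc(S(=O)(=O)N2CCC[C@@H](C(=O)N3CC[C@H](OC)C3)C2)cc1` differs from compound 2 in one place: 3-methoxypyrrolidin-1-yl in place of (oxan-4-yl)amino on a carbonyl carbon. Among the compounds with values here, no measured pair shows this change on its own. Compound 1, which also has no hydrogen-bond donor on this carbonyl carbon, gives 50 nM in this assay. A moderate fall in the number is therefore expected, a 7.1-fold lower number from compound 2 to compound 3 (0.85 log units; beyond the scatter), with wide uncertainty. Compound 3 is expected to give 1200 nM, within 150 nM to 8000 nM.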

Compound 3, half-maximal inhibitory concentration: 6750 nM
Compound 3: the middle estimate sits 5.6-fold (0.75 log units) below what was measured; measured number inside the range.
By their numbers in this assay, from the lowest: compound 1; then compounds 3 and 2 (each within the scatter of the next).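

In this assay, putting 3-methoxypyrrolidin-1-yl in place of (oxan-4-yl)amino on a carbonyl carbon gives a 1.3-fold lower number from compound 2 to compound 3 (0.10 log units; within the scatter). Losing the hydrogen-bond donor at this position, together with the change of ring, therefore leaves the number within the scatter in this pair. No measurement shown explains this result. Compound 1 differs from compound 2 and compound 3 in more than one place, so the compounds shown leave open which difference goes with its much lower number. Also open, from the compounds shown here alone, is how a morpholin-4-yl group or a dimethylamino group on this carbonyl carbon would read.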